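Cytotoxicity notes on the cyclopentane diamide series

This account rests on a few compounds, and the source may have more. Where it says the series, first, only, none or still open, it means among the compounds named here.

Compound 2 `O=C(O)/C=C/c1ccc(NC(=O)C2(NC(=O)c3ccc4c(c3)nc(-c3ccccn3)n4C3CCCCC3)CCC2)cc1` carries a pyridin-2-yl group on the shared core. In an ADME assay on Huh-7 cells (Homo sapiens) for cytotoxicity (a higher number here means that more compound is tolerated, a lower number that less compound is tolerated), compound 2 reaches only a limit, > 10 uM. Compound 1 `Cn1cccc1-c1nc2cc(C(=O)NC3(C(=O)Nc4ccc(/C=C/C(=O)O)cc4)CCC3)ccc2n1C1CCCCC1` is the matching compound with 1-methyl-1H-pyrrol-2-yl in that place. In this assay compound 1 likewise gives only a limit, > 10 uM. The step that the two limits leave unreadable from compound 1 to compound 2 is therefore unreadable, and the limit of > 10 uM in this assay, at which 2 of the 2 values shown sit, is all the evidence this pair offers. Compound 3 `O=C(O)/C=C/c1ccc(NC(=O)C2(NC(=O)c3ccc4c(c3)nc(-c3ccccc3)n4C3CCCCC3)CCC2)cc1` is the unmeasured analogue; it differs from compound 2 in this way: phenyl in place of pyridin-2-yl on an aromatic carbon. Going by the values given here, the one measured step that bears on this exchange is unreadable, so nothing points to a shift in tolerated concentration. The step expected here, a step that the limit leaves unreadable from compound 2 to compound 3, is accordingly none beyond the scatter, and a limit is again the most likely outcome. Compound 3 is expected to give about 20 uM in this assay, within 8 uM to 60 uM.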

Compound 3, half-maximal toxic concentration: > 10 uM
Compound 3: only a limit was reported; the forecaster's own chance of this, stated with the estimate: 75%; the middle value does not contradict the limit.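

Compound 1, compound 2 and compound 3 each give only a limit in this assay, so no step among them can be read: the limit of > 10 uM in this assay, at which 3 of the 3 values shown sit.

Still open, going by these compounds, is where each compound's half-maximal toxic concentration lies beyond that limit, and whether exchanging these three groups changes it.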